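The compounds below may be only part of what the source reports. "The series", "measured", "known", "first", "only" and "open" are said of these compounds alone.

Working notes on the series.

Three compounds carry a number in a functional assay on the whole organism (strain Wistar Albino) for inhibition, with Rattus norvegicus as the target, read by paw edema, with a stated time of 3 h, at a dose of 20 mg/kg; on this read-out lower numbers stand for less inhibition and higher numbers for more inhibition at the one dose given (going by the name of the read-out). Compound 1 `COc1ccc(Cl)c(-c2nnc3sc(Cc4c[nH]c5ccc(OC)cc45)nn23)c1` gives 21.4% in this assay . Compound 2 `COc1ccc2[nH]cc(Cc3nn4c(-c5ccoc5C)nnc4s3)c2c1` gives 26.1% in this assay . Compound 3 `COc1ccc(Cl)c(-c2nnc3sc(Cc4c[nH]c5ccccc45)nn23)c1` gives 21.4% in this assay , level with compound 1 at the digits shown and together with it the lowest of the three numbers; its nearest neighbour is compound 1, its furthest compound 2, and every gap here sits within the usual scatter. The step of no change at the digits printed from compound 1 to compound 3 (within the scatter) covers hydrogen in place of methoxy on an aromatic carbon, and the step of a number 4.7 percentage points higher from compound 1 to compound 2 (within the scatter) covers the same swap of aryl groups that is now in question.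

Compound 4 `Cc1occc1-c1nnc2sc(Cc3c[nH]c4ccccc34)nn12` has not yet been measured. It differs from compound 3 thus: 2-methylfuran-3-yl in place of 2-chloro-5-methoxyphenyl on an aromatic carbon. Going by the values given here, the one step that bears on this change is the one from compound 1 to compound 2, which stayed within the scatter, so no step beyond the scatter is expected here either, at most a small upward drift in line with that precedent.

Compound 4 is therefore estimated at 26% in this assay , with a range from 17% to 35%. The expected step of a number 4.6 percentage points higher from compound 3 to compound 4 (within the scatter) follows the step of a number 4.7 percentage points higher from compound 1 to compound 2 (within the scatter).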

Compound 4, a percentage reported as inhibition, in the whole organism at one dose (the size of the read-out at that dose, not a potency): 26.5%
Beside the measured number, compound 4's estimate is 0.5 percentage points below it; the measured number falls inside the stated range.
By their numbers in this assay, from the lowest: compounds 1, 3, 2 and 4 (each within the scatter of the next).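

The swap of 2-chloro-5-methoxyphenyl for 2-methylfuran-3-yl, on the aromatic carbon between two ring nitrogen atoms, now gives a number 5.1 percentage points higher from compound 3 to compound 4 (within the scatter) in this assay, so the change has been read on a second core and its size holds: the same change on two cores in this assay, a number 4.7 percentage points higher (within the scatter) from compound 1 to compound 2 and a number 5.1 percentage points higher (within the scatter) from compound 3 to compound 4, 0.4 percentage points apart, within the scatter of two such steps

The other change, hydrogen in place of methoxy on an aromatic carbon, had been read only with 2-chloro-5-methoxyphenyl in place and is now also read with 2-methylfuran-3-yl, giving a number 0.4 percentage points higher from compound 2 to compound 4 (within the scatter), and the two readings agree: the same change on two cores in this assay, no change at the digits printed (within the scatter) from compound 1 to compound 3 and a number 0.4 percentage points higher (within the scatter) from compound 2 to compound 4, 0.4 percentage points apart, within the scatter of two such steps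

Every step here stays within the scatter, so neither change is shown to move the number, and neither shows any dependence on the other.

As far as these compounds go, whether a group of another kind at this place, such as a primary amine, a carboxylic acid or a longer alkyl chain, would carry the number beyond the scatter remains open. Also open, from the compounds shown here alone, is whether this flat picture would hold at another dose or another reading time, and a read-out at one dose gives no potency for any of the four compounds.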